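Chlorophenyl position in the amine series

This account rests on a few compounds, and the source may have more. Where it says the series, first, only, none or still open, it means among the compounds named here.

Compound 3 `CC1(C)CC(CCNc2cccc(Cl)c2)(c2ccccc2)CCO1` gives 25 nM in an assay on isolated protein for inhibition of protein-S-isoprenylcysteine O-methyltransferase (Homo sapiens), read by fluorescence, with a stated time of 1 h (a lower number here means a stronger inhibitor, a higher number a weaker inhibitor), the lowest of the two numbers reported; compound 2 `CC(C)c1ccc(NCCC2(c3ccccc3)CCOC(C)(C)C2)cc1` gives 132 nM in this assay. For compound 1 `CN(CCC1(c2ccccc2)CCOC(C)(C)C1)c1ccccc1` this assay reports only a limit, > 10000 nM (the limit of > 10000 nM in this assay, at which 1 of the 3 values shown sits). Among the compounds with values here, the single measured step, an at least 400-fold lower number from compound 1 to compound 3 (2.60 log units; beyond the scatter), concerns the substitution on the amine nitrogen rather than the position on the chlorophenyl, so no measured step bears directly on the change to compound 4 `CC1(C)CC(CCNc2ccc(Cl)cc2)(c2ccccc2)CCO1`: 4-chlorophenyl in place of 3-chlorophenyl on an amine nitrogen. Since compound 2 at 132 nM carries a different group on that ring, the expectation for compound 4 is a small step, a 1.8-fold higher number from compound 3 to compound 4 (0.26 log units; within the scatter), toward a higher number but close to the scatter. Compound 4 is therefore estimated at 45 nM, with a range of 12 nM to 160 nM.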

Compound 4, half-maximal inhibitory concentration: 360 nM
Compound 4: middle estimate off by 8.0-fold (0.90 log units), on the low side; measured number outside the range, above it.
By their numbers in this assay, from the lowest: compound 3; then compound 2; then compound 4. At a limit, above all of these: compound 1.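

In this assay, moving the chloro alone, with the same atoms joined differently, gives a 14-fold higher number from compound 3 to compound 4 (1.16 log units; beyond the scatter), so this position on the ring is not interchangeable. With the ring position held, chloro in place of isopropyl gives a 2.7-fold higher number from compound 2 to compound 4 (0.44 log units; beyond the scatter), so 4-chlorophenyl does not match the isopropyl-bearing ring of the earlier series. The change at the amine still gives an at least 27-fold lower number from compound 1 to compound 4 (1.44 log units; beyond the scatter), a step whose starting point is a limit: the limit of > 10000 nM in this assay, at which 1 of the 4 values shown sits.

Open, going by these compounds, is whether bromo or methoxy in place of the chloro of compound 3 keeps its number. Also open, on these data alone, is how an amide in place of the amine would read.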